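Ester to Hydroxymethyl on the Aryl Group of Compound 2

This account rests on a few compounds, and the source may have more. Where it says the series, first, only, none or still open, it means among the compounds named here.

Compound 1 `CC(C)c1cccc(C(C)C)c1NC(=O)NCC1(c2ccc(Cl)cc2)CCCC1`: 32 nM
Compound 2 `COC(=O)c1cccc(C2(CNC(=O)Nc3c(C(C)C)cccc3C(C)C)CCCC2)c1`: 34 nM

Within the data shown here, in an assay on microsomes for inhibition of acyl-CoA:cholesterol acyltransferase (Oryctolagus cuniculus) (on this read-out lower numbers stand for stronger inhibition and higher numbers for weaker inhibition), compound 2 gives 34 nM, and compound 1 gives 32 nM; since a 1.1-fold higher number from compound 1 to compound 2 (0.03 log units; within the scatter) lies within the scatter, compound 2 stands level with the only other compound measured. Compound 3 `CC(C)c1cccc(C(C)C)c1NC(=O)NCC1(c2ccc(CO)cc2)CCCC1` differs from compound 2 by 4-(hydroxymethyl)phenyl in place of 3-(methoxycarbonyl)phenyl on a saturated ring carbon. Among the measured compounds shown here, the one measured step, a 1.1-fold higher number from compound 1 to compound 2 (0.03 log units; within the scatter), also exchanged one aryl group for another and brought no change beyond the scatter, so for compound 3 no step beyond the scatter is expected, a 1.0-fold higher number from compound 2 to compound 3 (0.01 log units; within the scatter). Compound 3 is therefore estimated at 35 nM, within 12 nM to 100 nM.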

Compound 3, half-maximal inhibitory concentration: 26 nM
Compound 3: middle estimate off by 1.3-fold (0.13 log units), on the high side, within the range that was stated.
By their numbers in this assay, from the lowest: compounds 3, 1 and 2 (each within the scatter of the next).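

In this assay, hydroxymethyl takes the place of chloro with a 1.2-fold lower number from compound 1 to compound 3 (0.09 log units; within the scatter), and 4-(hydroxymethyl)phenyl takes the place of 3-(methoxycarbonyl)phenyl with a 1.3-fold lower number from compound 2 to compound 3 (0.12 log units; within the scatter). Among these compounds, the saturated ring carbon has now carried three different aryl groups, one of them with a hydrogen-bond donor, and no step among them lies beyond the scatter. Nothing available explains why these three stand level. Going by these compounds, whether a carboxylic acid, an amine or a longer chain on the aryl group would also stand level remains open. So does whether any group at this place moves the number beyond the scatter.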